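The source may hold more compounds than are shown below. What is called first, only, known or untested is meant among the compounds shown, and "the series" means these compounds.

Working notes on the series.

Compound 2 `Cn1cnnc1SCC(=O)Nc1ccc(-c2nc(-c3ccccc3)c(-c3ccccc3)n2C)cc1` gives 88% in a functional assay on HT-29 cells (Homo sapiens) for cytotoxicity, read by MTT assay, with a stated time of 24 h, tested at 80 ug/mL; on this read-out lower numbers stand for a weaker effect and higher numbers for a stronger effect at the one concentration tested. Within the data shown here, its only neighbour on the numbers so far is compound 1 `Cn1c(-c2ccc(NC(=O)CSc3nc4ccccc4s3)cc2)nc(-c2ccccc2)c1-c1ccccc1`, which gives 82.7% in this assay; the step of a number 5.3 percentage points higher from compound 1 to compound 2 (within the scatter) is within the scatter, so the two compounds are not told apart by this read-out, and compound 2 stands at the top of the two numbers only on paper.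

Compound 3 `Cc1nnc(SCC(=O)Nc2ccc(-c3nc(-c4ccccc4)c(-c4ccccc4)n3C)cc2)s1` is the next compound in the same place on the shared core: 5-methyl-1,3,4-thiadiazol-2-yl in place of 4-methyl-4H-1,2,4-triazol-3-yl on a sulfur. Among the measured compounds shown here, one measured step bears on this kind of change, the exchange of the group on the sulfur from compound 1 to compound 2, which gave a number 5.3 percentage points higher from compound 1 to compound 2 (within the scatter), a step within the scatter. On that single precedent no step beyond the scatter is expected for compound 3, so the expected step is a number 3 percentage points lower from compound 2 to compound 3 (within the scatter). The estimate for compound 3 in this assay is therefore 85%, with a range from 70% to 95%.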

Compound 3, a percentage reported as activity, at one concentration (the size of the read-out at that concentration, not a potency): 90.5%
Beside the measured number, compound 3's estimate is 5.5 percentage points below it, and the stated range covers the measured number.
By their numbers in this assay, from the lowest: compounds 1, 2 and 3 (each within the scatter of the next).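

In this assay, 5-methyl-1,3,4-thiadiazol-2-yl in place of 4-methyl-4H-1,2,4-triazol-3-yl on a sulfur gives a number 2.5 percentage points higher from compound 2 to compound 3 (within the scatter), and in place of 1,3-benzothiazol-2-yl it gives a number 7.8 percentage points higher from compound 1 to compound 3 (within the scatter). Among these compounds, this position has now carried three different aromatic ring groups, and no step among the three compounds lies beyond the scatter, including the exchange of a ring nitrogen for a ring sulfur at an unchanged count of heavy atoms. No available evidence bears on why the three numbers stay together.

From the compounds shown here alone, whether a group without a ring on this sulfur, such as an ethyl chain or a carboxylic acid, keeps the number within the scatter stays open. A read-out at one concentration also leaves open whether these three compounds differ in potency.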